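A few compounds are considered here, and "the series" means these few. Any claim that something is new, unique, unknown or untested is made for them only; others in the source may bear on it.

Measured so far:
- compound 1, `COc1nsc(OCCCOCCCOCCCOc2nsnc2-c2cccnc2)n1`: 251 nM
- compound 2, `COc1nsnc1OCCOCCOCCOc1nsnc1C1=CCCN(C)C1`: 631 nM

In an assay on A9L cells for binding affinity to muscarinic acetylcholine receptor M5 (Homo sapiens) (a lower number here means a stronger inhibitor, a higher number a weaker inhibitor), compound 1 gives 251 nM, the lower of the two numbers; compound 2 gives 631 nM in this assay, and the gap between the two lies beyond the usual scatter. Compound 3, `COc1nsnc1OCCCOCCCOCCCOc1nsnc1-c1cccnc1`, is built from the same atoms as compound 1, joined differently: a group of 7 heavy atoms (3 carbon, 2 nitrogen, 1 oxygen, 1 sulfur; one five-membered aromatic ring with 3 hetero atoms) in place of a group of 7 heavy atoms (3 carbon, 2 nitrogen, 1 oxygen, 1 sulfur; one five-membered aromatic ring with 3 hetero atoms), on an oxygen on a saturated carbon. The 3-methoxy-1,2,4-thiadiazol-5-yl group on one end of the chain gives way to a ring of the same size and the same atom count, attached at the same oxygen on a saturated carbon. Among the compounds with values here, no measured pair in this set isolates such a ring swap, so there is no direct guide to the size of the step. For compound 3 the expected outcome is a number close to that of compound 1, perhaps slightly lower, estimated at 200 nM with a range from 60 nM to 700 nM, which is expected to mean a step of a 1.3-fold lower number from compound 1 to compound 3 (0.10 log units; within the scatter) in this assay.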

Compound 3, inhibition constant: 100 nM
Estimate against measurement, compound 3: 2.0-fold (0.30 log units) above, within the range that was stated.
By their numbers in this assay, from the lowest: compound 3; then compound 1; then compound 2.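

Compound 1 and compound 3 hold the same atoms, so this pair shows that the way those atoms are joined in the end ring can change the result on its own: in this assay replacing the 3-methoxy-1,2,4-thiadiazol-5-yl group, on an oxygen on a saturated carbon, gives a 2.5-fold lower number from compound 1 to compound 3 (0.40 log units; beyond the scatter) and nothing else in the molecule differs. The step is modest but lies beyond the usual scatter, so this position responds to the ring's arrangement even though its counts of heavy atoms and hydrogen-bond acceptors stay the same. Nothing measured here gives a reason for the step.

Still open, as far as these compounds go, is whether an ethoxy group or an amine in place of the methoxy group would move the number further. Also open, from the compounds shown here alone, is whether the same ring swap gives a step of similar size on a longer chain.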